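A few compounds are considered here, and "the series" means these few. Any claim that something is new, unique, unknown or untested is made for them only; others in the source may bear on it.

Compound 2 `COc1cc(NC(C)CCCNC(=O)NCc2ccccc2)c2ncccc2c1` gives 30000 nM in a functional assay on NCI-H460 cells (Homo sapiens), read by MTT assay, with a stated time of 72 h (a lower number here means a stronger inhibitor, a higher number a weaker inhibitor), the lowest of the two numbers in this small set. Its nearest neighbour is compound 3 `COc1cc(NC(C)CCCNC(=O)NC2CCCCC2)c2ncccc2c1`, which gives 77000 nM in this assay, separated from it by a 2.6-fold higher number from compound 2 to compound 3 (0.41 log units; beyond the scatter). Compound 1 `COc1cc(NC(C)CCCNC(=O)NC(c2ccccc2)c2ccccc2)c2ncccc2c1` reaches only a limit in this assay, > 100000 nM. That value is the limit of > 100000 nM in this assay, at which 1 of the 3 values shown sits. From compound 1 the change an at least 3.3-fold lower number from compound 1 to compound 2 (0.52 log units; beyond the scatter) lowers the number.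

Compound 4 `COc1cc(NC(C)CCCNC(=O)NCC2CCCCC2)c2ncccc2c1` is the next step out from compound 2: cyclohexyl in place of phenyl on a saturated chain carbon bound to an amide-type nitrogen. Within the data shown here, two measured steps bear on it. The step of a 2.6-fold higher number from compound 2 to compound 3 (0.41 log units; beyond the scatter) replaced benzyl with cyclohexyl and cost a modest amount, while an at least 3.3-fold lower number from compound 1 to compound 2 (0.52 log units; beyond the scatter) removed a phenyl from a saturated chain carbon and gave a lower number. Neither step copies the present exchange exactly, so a modest rise in this assay, or no step beyond the scatter, is expected. Compound 4 is therefore expected to give 50000 nM in this assay, within the range 18000 nM to 140000 nM, an estimated step of a 1.7-fold higher number from compound 2 to compound 4 (0.22 log units; within the scatter).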

Compound 4, half-maximal inhibitory concentration: > 100000 nM
Compound 4: no number, only a limit; the forecaster's own chance of this, stated with the estimate: 20%; at least 2.0-fold (0.30 log units) between middle value and limit.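

The result isolates the ring itself: phenyl and cyclohexyl each bring 6 heavy atoms, yet the step of an at least 3.3-fold higher number from compound 2 to compound 4 (0.52 log units; beyond the scatter) shows that in this assay, the aromatic ring on this saturated chain carbon bound to an amide-type nitrogen cannot be exchanged for the non-aromatic one without a rise in the number. The earlier steps shown here removed a phenyl or replaced benzyl with cyclohexyl, so neither tested this exchange with the chain carbon kept in place. Compound 4 gives a limit of the assay and not a number: the limit of > 100000 nM in this assay, at which 2 of the 4 values shown sit.

Among these compounds, the step of an at least 1.2-fold higher number from compound 3 to compound 4 (0.11 log units; that floor lies within the scatter) gives no order for that pair, and how far compound 4 lies past its limit stays open. Also open, going by these compounds, is whether a pyridyl ring, or a phenyl carrying an amine or a carboxylic acid, at this place would lower the number below that of compound 2.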